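A few compounds are considered here, and "the series" means these few. Any claim that something is new, unique, unknown or untested is made for them only; others in the source may bear on it.

Compound 3 `Cc1nc(C)c([C@H](OC(C)(C)C)C(=O)O)c(N2CCC(C)(C)CC2)c1-c1ccc(CCCc2ccc(F)cc2)cc1` sits at the upper end of the numbers seen so far: in an ADME assay on microsomes from liver (Rattus norvegicus) for metabolic stability, read by LC-MS, tested at 0.5 uM (on this read-out lower numbers stand for a shorter-lived compound and higher numbers for a longer-lived compound), compound 3 gives > 2 h, which is a limit rather than a number. Compound 1 `COc1ccc(CCOc2ccc(-c3c(C)nc(C)c([C@H](OC(C)(C)C)C(=O)O)c3N3CCC(C)(C)CC3)cc2)cc1` gives > 2 h, also a limit. Compound 2 `Cc1nc(C)c([C@H](OC(C)(C)C)C(=O)O)c(N2CCC(C)(C)CC2)c1-c1ccc(OCCc2ccc(F)c(F)c2)cc1` gives 0.85 h. Of the measured steps touching compound 3, one is an at least 2.3-fold higher number from compound 2 to compound 3 (0.37 log units; beyond the scatter) and the other step that the two limits leave unreadable from compound 1 to compound 3; the limit of > 2 h in this assay, at which 2 of the 3 values shown sit, is the reason the latter cannot be sized. Compound 4 `Cc1ncsc1CCOc1ccc(-c2c(C)nc(C)c([C@H](OC(C)(C)C)C(=O)O)c2N2CCC(C)(C)CC2)cc1` differs from compound 3 by 2-(4-methyl-1,3-thiazol-5-yl)ethoxy in place of 3-(4-fluorophenyl)propyl on an aromatic carbon. Among the compounds with values here, no measured step exchanges the 3-(4-fluorophenyl)propyl for an ethoxy-linked ring, but compound 2, which carries such a ring, gives 0.85 h. Compound 4 is therefore expected to show an at least 1.4-fold lower number from compound 3 to compound 4 (0.15 log units; that floor lies within the scatter). Compound 4 is estimated at 1.4 h, within 0.6 h to 3 h.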

Compound 4, half-life: > 2 h
Compound 4 gave a limit, no number (the forecaster's own chance of this, stated with the estimate: 35%); middle value at least 1.4-fold (0.15 log units) from the limit.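

Holding the ethoxy link fixed, 4-methyl-1,3-thiazol-5-yl in place of 3,4-difluorophenyl gives an at least 2.3-fold higher number from compound 2 to compound 4 (0.37 log units; beyond the scatter) in this assay, so the short value of compound 2 does not extend to every ring on this link. The result for compound 4 is a limit, not a number. The steps from compound 1 and compound 3 to compound 4 cannot be read: the limit of > 2 h in this assay, at which 3 of the 4 values shown sit.

As far as these compounds go, the order among compound 1, compound 3 and compound 4 remains open. A 2-(4-fluorophenyl)ethoxy group at this position would separate the effect of the link from that of the ring.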